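The source may report more compounds than this note shows. Statements on the series, on what has been measured and on what is new or still open speak of the compounds shown alone.

Compound 1 (`O=C(CCC1=CCCN(Cc2ccc(F)cc2)C1=O)NO`) carries a 4-fluorophenyl group on a saturated chain carbon bound to an amide-type nitrogen in a ring. In a functional assay on ACHN cells (Homo sapiens) for inhibition, read by sulforhodamine B assay (on this read-out lower numbers stand for stronger inhibition of growth and higher numbers for weaker inhibition of growth), compound 1 is reported as "not determined" (no result reported), so it offers no number to start from. Compound 2 (`O=C(CCC1=CCCN(Cc2ccc(NC(=O)c3ccccc3)cc2)C1=O)NO`) gives > 10000 nM in this assay, and this is a limit and not a number. The only reference point on the numbers shown is therefore (the limit of > 10000 nM in this assay, at which 1 of the 2 values shown sits).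

Compound 3 (`Cc1ccccc1CN1CCC=C(CCC(=O)NO)C1=O`) has 2-methylphenyl in place of 4-fluorophenyl at that same place on the core of compound 1, and the change counts as 2-methylphenyl in place of 4-fluorophenyl on a saturated chain carbon bound to an amide-type nitrogen in a ring. Both groups are six-membered aromatic rings of carbon only. For the measured compounds named here, no measured pair shows what such a swap does, so no step beyond the usual scatter is expected in this assay, in either direction. The nearest guide is compound 2 at > 10000 nM, again a limit, so weak inhibition of growth is expected. For compound 3 the estimated value is 12000 nM, with an expected range from 3000 nM to 40000 nM.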

Compound 3, concentration for 50% growth inhibition: > 10000 nM
Compound 3: a limit, no number (the forecaster's own chance of this, stated with the estimate: 60%); the middle value is on the limit's open side.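

Compound 3 gives > 10000 nM in this assay, which is a limit and not a number. No step can be read among compound 1, compound 2 and compound 3. As far as these compounds go, what remains open is what 2-methylphenyl in place of 4-fluorophenyl does to inhibition of growth, and how these compounds rank against one another.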